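The source may hold more compounds than are shown below. What is called first, only, known or untested is meant among the compounds shown, and "the series" means these compounds.

Compound 1 `Cc1nc(S(C)(=O)=O)ccc1Oc1ncnc(OC2CCN(C(=O)OC3(C(F)(F)F)CCC3)CC2)c1F` gives 63.3 nM in a functional assay on isolated protein for inhibition of Glucose-dependent insulinotropic receptor (Rattus norvegicus), read by HTRF and cAMP accumulation; on this read-out lower numbers stand for an effect already at smaller amounts and higher numbers for an effect only at larger amounts of compound. Compound 2 `Cc1nc(S(C)(=O)=O)ccc1Oc1ncnc(OC2CCN(C(=O)SC(C)C)CC2)c1F` gives 41.3 nM. Compound 3 `Cc1nc(S(C)(=O)=O)ccc1Oc1ncnc(OC2CCN(C(=O)SC3CC3)CC2)c1F` gives 126 nM.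

Compound 3 has the highest of the three numbers; the measured steps are a 2.0-fold higher number from compound 1 to compound 3 (0.30 log units; within the scatter) and a 3.1-fold higher number from compound 2 to compound 3 (0.48 log units; beyond the scatter). Compound 4 `Cc1nc(S(C)(=O)=O)ccc1Oc1ncnc(OC2CCN(C(=O)C(F)(F)F)CC2)c1F` carries a group of 4 heavy atoms (1 carbon, 3 fluorine; no ring) in place of a group of 4 heavy atoms (3 carbon, 1 sulfur; one three-membered non-aromatic ring of carbon only), on a carbonyl carbon. The measured steps at this carbonyl carbon, a 1.5-fold lower number from compound 1 to compound 2 (0.19 log units; within the scatter) and a 3.1-fold higher number from compound 2 to compound 3 (0.48 log units; beyond the scatter), show that such exchanges shift this assay only modestly. For compound 4 the expected step is a 1.8-fold lower number from compound 3 to compound 4 (0.26 log units; within the scatter), a move back toward the region of compounds 1 and 2. Compound 4 is estimated at 70 nM, with a range from 25 nM to 200 nM.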

Compound 4, half-maximal effective concentration: 880 nM
Compound 4: the middle estimate sits 13-fold (1.10 log units) below what was measured; the measured number lies above the stated range.
By their numbers in this assay, from the lowest: compounds 2, 1 and 3 (each within the scatter of the next, the first and the last beyond it); then compound 4.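

Among these compounds, the earlier exchanges at this carbonyl carbon stayed modest, whereas trifluoromethyl brings the first large steps in this assay (a 21-fold higher number from compound 2 to compound 4 (1.33 log units; beyond the scatter); a 14-fold higher number from compound 1 to compound 4 (1.14 log units; beyond the scatter)) and a further modest one (a 7.0-fold higher number from compound 3 to compound 4 (0.84 log units; beyond the scatter)). Trifluoromethyl and the group it replaces in compound 3 hold the same count of heavy atoms, so that count alone does not set the number here. No available evidence accounts for this shift. The compounds shown leave open whether the change follows from losing the sulfur or oxygen on the carbonyl carbon or from trifluoromethyl itself. A methyl or isopropoxy group there would help separate these.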